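Dichlorophenyl in Place of Aminophenyl: Expected Cytotoxicity

A few compounds are considered here, and "the series" means these few. Any claim that something is new, unique, unknown or untested is made for them only; others in the source may bear on it.

Of the compounds shown here, two have been measured in a functional assay on IGROV-1 cells (Homo sapiens) for cytotoxicity, read by sulforhodamine B assay, with a stated time of 48 h, tested at 0.01 uM; on this read-out higher numbers stand for a weaker effect at the one concentration tested and lower numbers for a stronger effect. Compound 1 `COc1cc(-c2cc(/C=C/C(=O)c3ccc(N)cc3)[nH]n2)cc(OC)c1OC` gives 107% in this assay, and compound 2 `COc1ccc(-c2cc(/C=C/C(=O)c3ccc(OC)c(OC)c3)[nH]n2)cc1` gives 97%. Compound 1 holds the higher of the two numbers, yet the gap to compound 2 lies within the usual scatter, so the two cannot be told apart; both numbers point to little effect at this concentration. The unmeasured compound 3 `COc1cc(-c2cc(/C=C/C(=O)c3ccc(Cl)c(Cl)c3)[nH]n2)cc(OC)c1OC` differs from compound 1 in one place: 3,4-dichlorophenyl in place of 4-aminophenyl on a carbonyl carbon. Going by the values given here, no measured pair shows what such a change does in this assay, so the expectation rests on compound 1 alone. Compound 1 stands at 107%. A step of a number 7 percentage points lower from compound 1 to compound 3 (within the scatter) is expected, which means no step beyond the scatter. Compound 3 is therefore expected to give 100% in this assay, with a likely range from 85% to 115%.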

Compound 3, a percentage reported as activity, at one concentration (the size of the read-out at that concentration, not a potency): 97%
Beside the measured number, compound 3's estimate is 3 percentage points above it, and the stated range covers the measured number.
By their numbers in this assay, from the lowest: compounds 2, 3 and 1 (each within the scatter of the next).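

In this assay, going by these compounds alone, the first pair that differs only on the carbonyl carbon shows a step of a number 10 percentage points lower from compound 1 to compound 3 (within the scatter), when 3,4-dichlorophenyl takes the place of 4-aminophenyl. So at this one concentration, exchanging a ring with one hydrogen-bond donor and one acceptor for a ring with neither, and with two chlorines, leaves no difference that can be told from scatter. No measurement at hand bears on why the read-out stays put.

From the compounds shown here alone, it remains open whether a group of another kind on this carbonyl carbon, such as a carboxylic acid, a morpholine ring or a longer alkyl chain, would move the number beyond the scatter. The pair also cannot show whether compound 1 and compound 3 would separate at other concentrations.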